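The compounds below may be only part of what the source reports. "The series", "measured", "known", "first", "only" and "open" are said of these compounds alone.

The measured compounds, each in a functional assay on MCF7 cells (Homo sapiens) for antiproliferative activity; on this read-out lower numbers stand for stronger inhibition and higher numbers for weaker inhibition:

- Compound 1 `CC(C)=CCc1cc(C(=O)Nc2cc3ccc(Oc4ccc(C(C)(C)C)cc4)c(C)c3oc2=O)ccc1O`: compound 1 gives 20600 nM.
- Compound 2 `COc1cccc(-c2cc(C(=O)Nc3cc4ccc(Oc5ccc(C(C)(C)C)cc5)c(C)c4oc3=O)ccc2OC)c1`: compound 2 reaches only a limit, > 100000 nM.
- Compound 3 `COc1ccc(Nc2ccc3cc(NC(=O)c4ccc(O)c(CC=C(C)C)c4)c(=O)oc3c2C)cc1`: compound 3 also reaches only a limit, > 100000 nM.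

Compounds 1 and 2 share a core but differ in more than one place; how the two cores differ is not broken down here. Compound 3 arises from compound 1 by a single change ((4-methoxyphenyl)amino in place of 4-(tert-butyl)phenoxy on an aromatic carbon), and this change made the step of an at least 4.8-fold higher number from compound 1 to compound 3 (0.68 log units; beyond the scatter); the number for compound 3 is the limit described in the limit of > 100000 nM in this assay, at which 2 of the 3 values shown sit, so the size of the step is known only as a lower bound.

The unmeasured compound 4 `COc1ccc(Nc2ccc3cc(NC(=O)c4ccc(OC)c(-c5cccc(OC)c5)c4)c(=O)oc3c2C)cc1` arises from compound 2 by the same change ((4-methoxyphenyl)amino in place of 4-(tert-butyl)phenoxy on an aromatic carbon); the surroundings of the place are the same word for word, so it is the same change. Since compound 2 already sits at the limit, the expected step that the limit leaves unreadable from compound 2 to compound 4 cannot be resolved in this assay, and the expectation rests on compound 2 giving > 100000 nM and on the earlier step of an at least 4.8-fold higher number from compound 1 to compound 3 (0.68 log units; beyond the scatter), which raised the number rather than lowering it. Compound 4 is therefore expected to give about 150000 nM, most likely reported again as a limit, with a range from 100000 nM to 300000 nM.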

Compound 4, half-maximal inhibitory concentration: > 100000 nM
Compound 4: no number, only a limit (the forecaster's own chance of this, stated with the estimate: 85%); the middle value is on the limit's open side.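

In this assay, within the data shown here, compound 2 and compound 4 both rest at a limit and give no number, so no step between them can be read: the limit of > 100000 nM in this assay, at which 3 of the 4 values shown sit. The compounds shown leave open whether (4-methoxyphenyl)amino in place of 4-(tert-butyl)phenoxy changes the read-out at all on the core of compound 2, and what actual numbers compound 2 and compound 4 would give.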